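The compounds below may be only part of what the source reports. "The series", "measured", "known", "first", "only" and "open" are said of these compounds alone.

Working notes on the series. In a functional assay for inhibition, with Rattus norvegicus as the target (on this read-out lower numbers stand for stronger inhibition and higher numbers for weaker inhibition), compound 1 `CC(C)C/N=c1\c(O)c(O)\c1=N/Cc1ccc(C#N)cc1` gives 10200 nM, compound 2 `CC(/N=c1\c(O)c(O)\c1=N/Cc1ccc(C#N)cc1Cl)C(C)(C)C` gives 180 nM, and compound 3 `CC1(C)Oc2ccc(OC(F)(F)F)cc2[C@@H](N2Cc3ccccc3C2=O)[C@@H]1O` gives 30 nM. Compound 2 stands second highest of these three numbers: compound 3 is nearest, with a number that lies beyond the scatter below it, while compound 1 sits furthest, beyond the scatter above it. Compound 4 `CC(/N=c1\c(O)c(O)\c1=N/Cc1ccc(Cl)cc1Cl)C(C)(C)C` has not yet been measured. It differs from compound 2 in one place: chloro in place of cyano on an aromatic carbon. Among the measured compounds shown here, no measured pair in this set isolates that change, so nothing here sizes it directly. In this assay the expected step is small, a 1.4-fold higher number from compound 2 to compound 4 (0.14 log units; within the scatter), probably within the scatter. Compound 4 is therefore estimated at 250 nM, with a range from 60 nM to 1000 nM.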

Compound 4, half-maximal inhibitory concentration: 340 nM
The estimate for compound 4 lay 1.4-fold (0.13 log units) below the measured number, within the range that was stated.
By their numbers in this assay, from the lowest: compound 3; then compounds 2 and 4 (each within the scatter of the next); then compound 1.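

Among the compounds shown here, the first pair to isolate this change shows that, in this assay, chloro in place of cyano on this aromatic carbon, para to a large group and meta to a chloro group, gives a 1.9-fold higher number from compound 2 to compound 4 (0.28 log units; within the scatter). At this position, with the rest of compound 2 held constant, the cyano group with its triple bond and hydrogen-bond acceptor is therefore not needed to keep the number within the scatter. No supporting measurement bears on this result.

Going by these compounds, whether an amine, a carboxylic acid or a methoxy group at this position would also stay within the scatter remains open. So does whether the same exchange would read alike on the core of compound 1.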